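Methyl in Place of Chloro: Cytotoxicity Expected for Compound 3

The source may report more compounds than this note shows. Statements on the series, on what has been measured and on what is new or still open speak of the compounds shown alone.

Among the compounds with values here, compound 2, `N#Cc1ccc(Nc2nccc(Oc3ccc(-c4ccc(C#N)cc4)cc3Cl)n2)cc1`, is one of two compounds measured in a functional assay on MT4 cells (Homo sapiens) for cytotoxicity, read by MTT assay, with a stated time of 5 days; a lower number here means that less compound is tolerated, a higher number that more compound is tolerated. In this assay compound 2 gives > 295000 nM, which is a limit of the assay rather than a number. Its neighbour compound 1, `N#Cc1ccc(Nc2nccc(Oc3ccc(-c4ccc(C#N)cc4Cl)cc3Cl)n2)cc1`, carries an additional chloro on an aromatic carbon. In this assay compound 1 gives > 273000 nM, again a limit of the assay and not a number. Within the data shown here, the one measured step, a step that the two limits leave unreadable from compound 1 to compound 2, cannot be read in size, as the limit of > 273000 nM in this assay, at which 1 of the 2 values shown sits, and the limit of > 295000 nM in this assay, at which 1 of the 2 values shown sits, together show.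

Compound 3, `Cc1cc(-c2ccc(C#N)cc2)ccc1Oc1ccnc(Nc2ccc(C#N)cc2)n1`, is not yet measured. It differs from compound 2 by methyl in place of chloro on an aromatic carbon. Among the measured compounds shown here, only the step from compound 1 to compound 2 bears on this change, and since both of its ends sit at limits, it tells neither size nor direction. With both measured compounds at limits, compound 3 is expected to remain at or near the limit, so the expected step that the limit leaves unreadable from compound 2 to compound 3 is none beyond the scatter. Compound 3 is therefore estimated at 300000 nM, within a range from 100000 nM to 700000 nM.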

Compound 3, half-maximal cytotoxic concentration: > 310000 nM
Compound 3 was reported as a limit; the forecaster's own chance of this, stated with the estimate: 85%; middle value at least 1.0-fold (0.01 log units) from the limit.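

In this assay compound 3 gives > 310000 nM, which is a limit of the assay and not a number. The step between compound 2 and compound 3 therefore cannot be read, in size or in direction. The compounds shown leave open where the half-maximal cytotoxic concentration of compound 1, compound 2 or compound 3 actually lies, and whether methyl in place of chloro changes it.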